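Fluoro Added Where Three Sulfonamides Sit at the Limit

The source may hold more compounds than are shown below. What is called first, only, known or untested is meant among the compounds shown, and "the series" means these compounds.

Compound 1 `O=S(=O)(Nc1ccc2oc(-c3ccccc3)nc2c1)c1cccc(C(F)(F)F)c1` is measured in an assay on isolated protein for inhibition of malate dehydrogenase, mitochondrial (Sus scrofa), with stated times of 45 min and 30 min (on this read-out higher numbers stand for weaker inhibition and lower numbers for stronger inhibition), where compound 1 gives only the limit > 63000 nM rather than a number. Compound 2 `Cc1ccccc1S(=O)(=O)Nc1ccc2oc(-c3ccccc3)nc2c1` in this assay likewise gives a limit, > 63000 nM. Compound 3 `O=S(=O)(Nc1ccc2oc(-c3ccccc3)nc2c1)c1cccc(F)c1` in this assay also gives a limit, > 63000 nM. Because (the limit of > 63000 nM in this assay, at which 3 of the 3 values shown sit), the size of the step that the two limits leave unreadable from compound 1 to compound 3 cannot be read, and the same holds for a step that the two limits leave unreadable from compound 2 to compound 3. Compound 4 `O=S(=O)(Nc1ccc2oc(-c3ccccc3)nc2c1)c1ccc(F)c(C(F)(F)F)c1` differs from compound 1 by fluoro in place of hydrogen on an aromatic carbon. Neither measured step yields a readable size, so no direction for this change can be drawn from them. With all three values shown sitting at the limit, compound 4 is expected to stay in the same region, with the step that the limit leaves unreadable from compound 1 to compound 4 estimated as none beyond the scatter. In this assay compound 4 is therefore estimated at 90000 nM, within 30000 nM to 300000 nM, most likely again reported only as a limit.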

Compound 4, half-maximal inhibitory concentration: > 63000 nM
Compound 4 gave a limit, no number; the forecaster's own chance of this, stated with the estimate: 80%; the middle value is on the limit's open side.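

In this assay compound 1 and compound 4 both stand only as limits, and the step between them cannot be read. The compounds shown leave open whether any compound of this kind inhibits the enzyme measurably, and which change, if any, would give a readable number.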